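Amide to urea on the shared core: cytotoxicity notes

This account rests on a few compounds, and the source may have more. Where it says the series, first, only, none or still open, it means among the compounds named here.

Compound 1 `COC(=O)c1ccc2c(ccn2-c2cccc(NC(=O)c3cccc(C(F)(F)F)c3)c2)n1` is one of three compounds assessed in an ADME assay on HS27 cells (Homo sapiens) for cytotoxicity, read by MTT assay; a lower number here means a stronger inhibitor, a higher number a weaker inhibitor. Compound 1 gives > 10000 nM, a limit of the assay rather than a number. Compound 2 `COC(=O)c1ccc2c(ccn2-c2ccc(NC(=O)c3ccc(Cl)c(C(F)(F)F)c3)cc2)n1` gives 2900 nM in this assay. Compound 3 `COC(=O)c1ccc2c(ccn2-c2ccc(NC(=O)Nc3cccc(Cl)c3Cl)cc2)n1` gives > 10000 nM, also a limit. The change from compound 1 to compound 4 `COC(=O)c1ccc2c(ccn2-c2cccc(NC(=O)Nc3cccc(C(F)(F)F)c3)c2)n1` is (3-(trifluoromethyl)phenyl)amino in place of 3-(trifluoromethyl)phenyl on a carbonyl carbon. Going by the values given here, the one measured step of the same kind, an amino group inserted between the carbonyl carbon and the aryl ring, is an at least 3.4-fold higher number from compound 2 to compound 3 (0.53 log units; beyond the scatter), ending at the limit of > 10000 nM in this assay, at which 2 of the 3 values shown sit. Compound 1 already sits at that limit, so the step that the limit leaves unreadable from compound 1 to compound 4 is expected to hold compound 4 at the limit as well. Compound 4 is therefore estimated at 20000 nM, with a range of 8000 nM to 60000 nM, most likely reported only as a limit.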

Compound 4, half-maximal inhibitory concentration: > 10000 nM
Compound 4 gave a limit, no number; the forecaster's own chance of this, stated with the estimate: 85%; the middle value does not contradict the limit.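

Compound 1 and compound 4 both give only a limit, so no step between them can be read: the limit of > 10000 nM in this assay, at which 3 of the 4 values shown sit.

From the compounds shown here alone, how far (3-(trifluoromethyl)phenyl)amino in place of 3-(trifluoromethyl)phenyl shifts cytotoxicity in this assay remains open.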